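Permeability of a quinoline-free series: phenyl, benzyl, methoxyphenyl

The source may hold more compounds than are shown below. What is called first, only, known or untested is meant among the compounds shown, and "the series" means these compounds.

Compound 1 `COc1ccc(F)cc1CNCCCNc1ccnc2cc(CC(C)C)ccc12` gives 23 10^-6 cm/s in an ADME assay for permeability, using PAMPA, with a stated time of 30 min, at pH 7.4; a higher number here means that the compound crosses the layer faster, a lower number that the compound crosses the layer more slowly.
Compound 2 `COc1ccc(F)cc1CNCCCNc1ccnc2cc(-c3ccccc3)ccc12` gives 237 10^-6 cm/s in this assay.
Compound 3 `COc1ccc(F)cc1CNCCCNc1ccnc2cc(Cc3ccccc3)ccc12` gives 23 10^-6 cm/s in this assay.

Compound 3 stands level with compound 1, the two together at the bottom of the three numbers, with no change at the digits printed from compound 1 to compound 3 (within the scatter). Compound 2 sits well apart: a 10-fold lower number from compound 2 to compound 3 (1.01 log units; beyond the scatter), and a 10-fold higher number from compound 1 to compound 2 (1.01 log units; beyond the scatter).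

Compound 4 `COc1ccc(-c2ccc3c(NCCCNCc4cc(F)ccc4OC)ccnc3c2)cc1` is the next step from compound 3: 4-methoxyphenyl in place of benzyl on an aromatic carbon. Going by the values given here, the one measured step that bears on it is the move from benzyl to phenyl on the same aromatic carbon, seen in the gap between compound 3 and compound 2, which was large. Compound 4 carries an aryl group directly on that carbon, as compound 2 does, and so a large rise is expected in this assay, about a 6.5-fold higher number from compound 3 to compound 4 (0.81 log units; beyond the scatter). Compound 4 is therefore estimated at 150 10^-6 cm/s, within 60 10^-6 cm/s to 320 10^-6 cm/s.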

Compound 4, apparent permeability: 237 10^-6 cm/s
Compound 4: middle estimate off by 1.6-fold (0.20 log units), on the low side, and the stated range covers the measured number.
By their numbers in this assay, from the lowest: compounds 1 and 3 (each within the scatter of the next); then compounds 2 and 4 (each within the scatter of the next).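

In this assay the methoxy group makes no difference to the directly attached aryl group, with no change at the digits printed from compound 2 to compound 4 (within the scatter) when methoxy replaces hydrogen. A second directly attached aryl group thus repeats the rise over the saturated carbon link, with a 10-fold higher number from compound 3 to compound 4 (1.01 log units; beyond the scatter) against benzyl and a 10-fold higher number from compound 1 to compound 4 (1.01 log units; beyond the scatter) against isobutyl on the same aromatic carbon. The high number therefore holds for a substituted aryl group as well as for plain phenyl.

From the compounds shown here alone, whether an amine or a carboxylic acid in place of the methoxy would keep the number at this level stays open. Nothing given here accounts for these steps.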